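Removing the Fluoro Group from Compound 2

The source may hold more compounds than are shown below. What is called first, only, known or untested is meant among the compounds shown, and "the series" means these compounds.

Measured so far:
compound 1, `Cc1ccc(/C=C/C(=O)NNC(=O)c2ccc3c(c2)OCCO3)cc1`: 1050 nM
compound 2, `O=C(/C=C/c1ccc(F)cc1)NNC(=O)c1ccc2c(c1)OCCO2`: 990 nM

Both compounds were tested in a functional assay on cells (Cancer cell lines, Homo sapiens) for inhibition, read by MTT assay, with a stated time of 48 h; a higher number here means a weaker inhibitor, a lower number a stronger inhibitor. Compound 2 stands at the lower of the two numbers, with compound 1 as its only neighbor, but the gap between them lies within the scatter, so neither can be called the stronger inhibitor. Among the measured compounds shown here, the single measured step, a 1.1-fold lower number from compound 1 to compound 2 (0.03 log units; within the scatter), shows that exchanging one small group for another on this aromatic carbon left the result essentially unchanged.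

Compound 3, `O=C(/C=C/c1ccccc1)NNC(=O)c1ccc2c(c1)OCCO2`, has not yet been measured. It differs from compound 2 by hydrogen in place of fluoro on an aromatic carbon. Because a 1.1-fold lower number from compound 1 to compound 2 (0.03 log units; within the scatter) concerned the same aromatic carbon and stayed within the scatter, the further change to a bare hydrogen is expected to bring only a modest shift in this assay, with a somewhat higher number judged slightly more likely than a lower one. Compound 3 is therefore expected to give 1200 nM, between 600 nM and 2500 nM, an expected step of a 1.2-fold higher number from compound 2 to compound 3 (0.08 log units; within the scatter).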

Compound 3, half-maximal inhibitory concentration: 550 nM
Estimate against measurement, compound 3: 2.2-fold (0.34 log units) above; measured number outside the range, below it.
By their numbers in this assay, from the lowest: compounds 3, 2 and 1 (each within the scatter of the next).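

The 4-fluorophenyl to phenyl change gives a 1.8-fold lower number from compound 2 to compound 3 (0.26 log units; within the scatter), and hydrogen in place of methyl gives a 1.9-fold lower number from compound 1 to compound 3 (0.28 log units; within the scatter). The earlier pair only exchanged one small group for another, whereas compound 3 shows that in this assay the ring needs no group at all on this carbon for the number to stay within the scatter of compound 1 and compound 2. Nothing available here explains why these three compounds read so much alike.

From the compounds shown here alone, it remains open whether this carbon would be equally undemanding with a methoxy group, an amine, a carboxylic acid or a longer chain in place of hydrogen. The compounds shown also leave open whether the same holds for a group elsewhere on this ring, or for changes to the shared core.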